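The source may hold more compounds than are shown below. What is called first, only, known or untested is meant among the compounds shown, and "the series" means these compounds.

Compound 1 `COc1cc(-c2cc(C(=O)O)sc2-c2cccc(Br)c2)cc(OC)c1OC` gives 32300 nM
Compound 2 `COc1cc(-c2cc(C(=O)O)sc2-c2ccc3ccccc3c2)cc(OC)c1OC` gives 5640 nM
Compound 3 `COc1ccc(-c2sc(C(=O)O)cc2-c2cc(OC)c(OC)c(OC)c2)cc1O` gives 11200 nM

All three values come from a functional assay on KB cells (Homo sapiens) for antiproliferative activity, read by MTT assay, with a stated time of 72 h (on this read-out lower numbers stand for stronger inhibition and higher numbers for weaker inhibition), and compound 1 has the highest number of the three. Compound 4 `COc1cc(-c2ccsc2-c2cccc(Br)c2)cc(OC)c1OC` is not yet measured. It differs from compound 1 by one change (hydrogen in place of carboxy on an aromatic carbon), which puts hydrogen in place of carboxy on an aromatic carbon, next to the ring sulfur. Among the measured compounds shown here, all three measured compounds carry the carboxy group, so no measured step shows what removing it does. The nearest evidence comes from replacing the 3-bromophenyl group. These steps were modest (a 5.7-fold lower number from compound 1 to compound 2 (0.76 log units; beyond the scatter); a 2.9-fold lower number from compound 1 to compound 3 (0.46 log units; beyond the scatter)), and one stayed within the scatter (a 2.0-fold higher number from compound 2 to compound 3 (0.30 log units; within the scatter)). They bear on this change only indirectly. Losing the whole carboxy group is a different kind of change, so a step larger than these is possible. Compound 1 (32300 nM) already has the highest number, so a lower number is the more likely direction, though this is uncertain. The expected step in this assay is an estimate (an 8.1-fold lower number from compound 1 to compound 4 (0.91 log units; beyond the scatter)). For compound 4 the estimated value is 4000 nM with an expected range from 300 nM to 40000 nM in this wide estimate.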

Compound 4, half-maximal inhibitory concentration: > 100000 nM
Compound 4: no number, only a limit; the forecaster's own chance of this, stated with the estimate: 15%; at least 25-fold (1.39 log units) between middle value and limit.
By their numbers in this assay, from the lowest: compounds 2 and 3 (each within the scatter of the next); then compound 1. At a limit, above all of these: compound 4.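

Compound 1, compound 2 and compound 3 all carry the carboxy group, so they showed only what happens when the 3-bromophenyl group is replaced, and nothing about the carboxy position itself. In this assay, hydrogen in place of carboxy, next to the ring sulfur, gives an at least 3.0-fold higher number from compound 1 to compound 4 (0.49 log units; beyond the scatter), so in this pair the inhibition is stronger with the carboxy group present. For compound 4 the result is a limit, not a number: the limit of > 100000 nM in this assay, at which 1 of the 4 values shown sits.

Going by these compounds, what a methyl ester or a primary amide would do at this position stays open, so it cannot be said whether the full carboxy group is required. Also open is whether losing carboxy has the same effect alongside the naphthalen-2-yl group of compound 2 or the 3-hydroxy-4-methoxyphenyl group of compound 3, as the only compound shown without carboxy carries 3-bromophenyl.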